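The compounds below may be only part of what the source reports. "The series", "measured", "known", "first", "only" and "open" are said of these compounds alone.

Working notes on the series.

Compound 1 `CCCCCCNc1nc(SCc2ccc(C(F)(F)F)cc2)nc2ccccc12` gives 19000 nM in a functional assay on PC-3 cells (Homo sapiens) for cytotoxicity, read by MTT assay, with a stated time of 72 h; a higher number here means a weaker inhibitor, a lower number a stronger inhibitor. Within the data shown here, compound 2 `FC(F)(F)c1ccc(CSc2nc(Nc3ccc(Cl)cc3)c3ccccc3n2)cc1` gives 7110 nM in this assay, and the one step measured so far, a 2.7-fold lower number from compound 1 to compound 2 (0.43 log units; beyond the scatter), concerns the group on the nitrogen on the aromatic ring. On these two numbers compound 2 stands lowest, with compound 1 the nearest neighbour.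

Compound 3 `Fc1ccc(Nc2nc(SCc3ccc(C(F)(F)F)cc3)nc3ccccc23)cc1Cl` is not yet measured. It differs from compound 2 by 3-chloro-4-fluorophenyl in place of 4-chlorophenyl on a nitrogen on an aromatic ring; the entering group keeps the chlorine and adds a fluorine. Among the measured compounds shown here, no measured step bears directly on this change: the step from compound 1 to compound 2 swaps a hexyl for an aryl group and says nothing about a second halogen on that aryl. For compound 3 the step is therefore expected to be small, a 1.2-fold lower number from compound 2 to compound 3 (0.07 log units; within the scatter), with no clear direction. Compound 3 is estimated at 6000 nM, within 2500 nM to 15000 nM.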

Compound 3, half-maximal inhibitory concentration: 18600 nM
Compound 3: middle estimate off by 3.1-fold (0.49 log units), on the low side; the measured number lies above the stated range.
By their numbers in this assay, from the lowest: compound 2; then compounds 3 and 1 (each within the scatter of the next).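

At the nitrogen on an aromatic ring, 3-chloro-4-fluorophenyl in place of 4-chlorophenyl gives a 2.6-fold higher number from compound 2 to compound 3 (0.42 log units; beyond the scatter) in this assay, so this position responds to the halogens on the aryl group and not only to the choice of aryl over hexyl. The lower number seen with 4-chlorophenyl therefore does not extend to every aryl group here: a 1.0-fold lower number from compound 1 to compound 3 (0.01 log units; within the scatter) leaves 3-chloro-4-fluorophenyl and hexyl not separated. No measurement at hand accounts for the difference between the two aryl groups.

The compounds shown do not separate the added fluorine from the changed place of the chlorine; 3-chlorophenyl and 4-fluorophenyl groups on the same nitrogen would be needed for that. Also open, as far as these compounds go, is how an unsubstituted phenyl or a 4-methoxyphenyl group would compare with 4-chlorophenyl at this position.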